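Nitrogen substituents in a small cytotoxic series

The source may hold more compounds than are shown below. What is called first, only, known or untested is meant among the compounds shown, and "the series" means these compounds.

In a functional assay on DU-145 cells (Homo sapiens) for cytotoxicity, read by trypan blue exclusion, with a stated time of 96 h (a higher number here means a weaker inhibitor, a lower number a stronger inhibitor), compound 3 `COc1cc(OC)c(/C=C/S(=O)(=O)Cc2ccc(OC)c(N[C@@H](C)C(=O)O)c2)c(OC)c1` gives 25 nM, the lowest number of the three measured. Compound 1 `COC(=O)C(Nc1cc(CS(=O)(=O)/C=C/c2c(OC)cc(OC)cc2OC)ccc1OC)c1ccc(Cl)cc1` gives 400 nM and compound 2 `COC(=O)C(Nc1cc(CS(=O)(=O)/C=C/c2c(OC)cc(OC)cc2OC)ccc1OC)c1ccc(Br)cc1` gives 300 nM, which is a 1.3-fold lower number from compound 1 to compound 2 (0.12 log units; within the scatter). Compound 3 stands well clear of both: a 16-fold lower number from compound 1 to compound 3 (1.20 log units; beyond the scatter), and a 12-fold lower number from compound 2 to compound 3 (1.08 log units; beyond the scatter). Compound 4 `COc1cc(OC)c(/C=C/S(=O)(=O)Cc2ccc(OC)c(NC(C(=O)O)c3ccc(Cl)cc3)c2)c(OC)c1` carries carboxy(4-chlorophenyl)methyl in place of 1-carboxyethyl on a nitrogen on an aromatic ring. Among the measured compounds shown here, those two large steps remove the halophenyl ring and the methoxycarbonyl together, and no measured pair separates them. Compound 4 restores only the ring, and part of a 16-fold lower number from compound 1 to compound 3 (1.20 log units; beyond the scatter) is expected to return. The estimate is a 2.8-fold higher number from compound 3 to compound 4 (0.45 log units; beyond the scatter). For compound 4 the expected value is 70 nM, within an estimated range of 20 nM to 250 nM.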

Compound 4, half-maximal inhibitory concentration: 400 nM
Beside the measured number, compound 4's estimate is 5.7-fold (0.76 log units) below it; measured number outside the range, above it.
By their numbers in this assay, from the lowest: compound 3; then compounds 2, 1 and 4 (each within the scatter of the next).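

In this assay, the ring, not the ester, now accounts for the gap: the free acid carrying carboxy(4-chlorophenyl)methyl gives up the whole advantage of compound 3 (a 16-fold higher number from compound 3 to compound 4 (1.20 log units; beyond the scatter)). Replacing methyl with hydrogen on the oxygen next to the carbonyl leaves no change at the digits printed from compound 1 to compound 4 (within the scatter), and the comparison with the bromo ester is also flat (a 1.3-fold higher number from compound 2 to compound 4 (0.12 log units; within the scatter)). No measurement on hand explains these steps.

On these data alone, whether a plain phenyl or a longer alkyl chain in place of the 4-chlorophenyl ring keeps the low number of compound 3 remains open. So does the result of a methyl ester on 1-carboxyethyl.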